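Aryl amide swaps on a bis-indole nitrile series

The source may hold more compounds than are shown below. What is called first, only, known or untested is meant among the compounds shown, and "the series" means these compounds.

Measured in a functional assay on HT-29 cells (Homo sapiens) for cytotoxicity, read by MTT assay, with a stated time of 72 h; on this read-out lower numbers stand for stronger inhibition and higher numbers for weaker inhibition:
compound 1 `COc1ccc(C(=O)NC[C@H]2c3[nH]c4ccccc4c3C[C@H]3[C@H]4c5[nH]c6ccccc6c5C[C@@H]([C@H](C#N)N23)N4C)cc1`: 840 nM
compound 2 `CN1[C@@H]2c3[nH]c4ccccc4c3C[C@H]1[C@H](C#N)N1[C@@H](CNC(=O)c3cc4ccccc4s3)c3[nH]c4ccccc4c3C[C@@H]21`: 640 nM

Compound 2 stands level with compound 1 within the scatter, the two differing only by a 1.3-fold lower number from compound 1 to compound 2 (0.12 log units; within the scatter). Compound 3 `CN1[C@@H]2c3[nH]c4ccccc4c3C[C@H]1[C@H](C#N)N1[C@@H](CNC(=O)c3cc4ccccc4[nH]3)c3[nH]c4ccccc4c3C[C@@H]21` has not yet been measured. It differs from compound 2 by 1H-indol-2-yl in place of 1-benzothiophen-2-yl on a carbonyl carbon. Among the measured compounds shown here, no measured step carries this exact exchange. For the measured compounds named here, the only step on the same carbonyl carbon, a 1.3-fold lower number from compound 1 to compound 2 (0.12 log units; within the scatter), replaced one aryl group with another and left the number within the scatter, so the measured pair gives no sign that the group on the carbonyl carbon moves the read-out much. The step of a 1.0-fold higher number from compound 2 to compound 3 (0.01 log units; within the scatter) in this assay is therefore expected to stay within the scatter, with no direction favoured. Compound 3 is estimated at 650 nM, with a range from 300 nM to 1400 nM.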

Compound 3, half-maximal inhibitory concentration: 1220 nM
For compound 3 the middle estimate is 1.9-fold (0.27 log units) below the measured one; the range from low to high includes it.
By their numbers in this assay, from the lowest: compounds 2, 1 and 3 (each within the scatter of the next).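

In this assay, replacing 1-benzothiophen-2-yl with 1H-indol-2-yl on the carbonyl carbon, an exchange of a ring sulfur for a ring nitrogen that brings in a hydrogen-bond donor, gives a 1.9-fold higher number from compound 2 to compound 3 (0.28 log units; within the scatter), and replacing 4-methoxyphenyl with the same group gives a 1.5-fold higher number from compound 1 to compound 3 (0.16 log units; within the scatter). Both steps stay within the scatter, so this position has now taken three different aryl groups, and introducing a hydrogen-bond donor there gives no separable change in the read-out for compound 1, compound 2 and compound 3. No available evidence bears on these numbers.

From the compounds shown here alone, it remains open whether the read-out would hold with a non-aromatic group on this carbonyl carbon, such as a cyclohexyl ring or a longer chain ending in an amine or a carboxylic acid. A methyl group on the amide-type nitrogen is equally untested in the compounds shown here.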